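Adding a methyl to compound 2

A few compounds are considered here, and "the series" means these few. Any claim that something is new, unique, unknown or untested is made for them only; others in the source may bear on it.

Compound 1 `N#Cc1c(-c2nnc(O)c3nn(-c4ccccc4)cc23)nn(-c2ccccc2)c1-c1ccccc1`: 92200 nM
Compound 2 `N#Cc1c(-c2nnc(-c3ccccc3)c3nn(-c4ccccc4)cc23)nn(-c2ccccc2)c1-c1ccccc1`: 94800 nM

In a functional assay on IGROV-1 cells (Homo sapiens) for inhibition, read by sulforhodamine B assay, with a stated time of 48 h (on this read-out lower numbers stand for stronger inhibition of growth and higher numbers for weaker inhibition of growth), compound 2 gives 94800 nM, level with compound 1 at 92200 nM, so the two cannot be told apart. Compound 3 `Cc1ccc(-n2cc3c(-c4nn(-c5ccccc5)c(-c5ccccc5)c4C#N)nnc(-c4ccccc4)c3n2)cc1` differs from compound 2 by one small change: methyl in place of hydrogen on an aromatic carbon. This puts methyl in place of hydrogen on an aromatic carbon, turning phenyl to 4-methylphenyl. For the measured compounds named here, only one measured step bears on it: a 1.0-fold higher number from compound 1 to compound 2 (0.01 log units; within the scatter). That step swapped a different group, so no measurement tests this methyl directly. Still, replacing hydroxy with phenyl stayed within the scatter, so no shift beyond the scatter is expected in this assay. The expected step is a 1.1-fold lower number from compound 2 to compound 3 (0.02 log units; within the scatter). For compound 3 the estimated value is 90000 nM, with an expected range from 40000 nM to 150000 nM.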

Compound 3, concentration for 50% growth inhibition: 93400 nM
For compound 3 the middle estimate is 1.0-fold (0.02 log units) below the measured one; low and high end bracket the measured number.
By their numbers in this assay, from the lowest: compounds 1, 3 and 2 (each within the scatter of the next).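

For the compounds shown here, this is the first direct test of a methyl at this place, para to a large group: in this assay going from phenyl to 4-methylphenyl gives a 1.0-fold lower number from compound 2 to compound 3 (0.01 log units; within the scatter). The position therefore takes this one added carbon without a shift that can be told from the scatter, as was also true of the swap at a different place, which gave a 1.0-fold higher number from compound 1 to compound 2 (0.01 log units; within the scatter). Nothing measured here explains why the number stays level.

Going by these compounds, whether an amine, a carboxylic acid or a longer chain at this same place would move the number beyond the scatter remains open. The methyl result also says nothing about changes to the nitrile or the other phenyl rings, which stay the same across compound 2 and compound 3.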